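A few compounds are considered here, and "the series" means these few. Any claim that something is new, unique, unknown or untested is made for them only; others in the source may bear on it.

Measured compounds:
`Cc1nc2cc(OC[C@H](O)CN3CCN(Cc4nc(-c5ccc(C(C)(C)C)cc5)no4)CC3)ccc2s1`, compound 1: 570 nM
`Cc1nc2cc(OC[C@H](O)CN3CCN(Cc4csc(-c5ccc(C(F)(F)F)cc5)n4)CC3)ccc2s1`, compound 2: 1300 nM

Compound 2 gives the highest number of the two in a functional assay on mitochondria from heart for inhibition of peroxisomal acyl-coenzyme A oxidase 1 (Rattus norvegicus); on this read-out lower numbers stand for stronger inhibition and higher numbers for weaker inhibition; compound 1 sits at a lower number, and that gap lies beyond the scatter. For the measured compounds named here, no step between measured compounds that differ in a single place is available. Compound 3, `Cc1nc2cc(OC[C@H](O)CN3CCN(Cc4nc(-c5ccc(C(F)(F)F)cc5)sc4C)CC3)ccc2s1`, differs from compound 2 by methyl in place of hydrogen on an aromatic carbon. Going by the values given here, with no comparable step measured, the change from compound 2 to compound 3 in this assay is expected to stay within the scatter, in either direction. Compound 3 is expected to give about 1100 nM in this assay, with a range from 400 nM to 3000 nM. That expectation means a 1.2-fold lower number from compound 2 to compound 3 (0.07 log units; within the scatter).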

Compound 3, half-maximal inhibitory concentration: 1500 nM
Beside the measured number, compound 3's estimate is 1.4-fold (0.13 log units) below it, and the stated range covers the measured number.
By their numbers in this assay, from the lowest: compound 1; then compounds 2 and 3 (each within the scatter of the next).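

In this assay, for the compounds shown here, methyl in place of hydrogen on an aromatic carbon next to the ring sulfur gives a 1.2-fold higher number from compound 2 to compound 3 (0.06 log units; within the scatter), the first single-place step. This position therefore accepts one added methyl with no shift beyond the scatter. No measurement available here accounts for this result.

Going by these compounds, whether a larger group at this carbon, such as ethyl, methoxy or a primary amine, also stays within the scatter of compound 2 remains open. Compound 1 differs from compound 2 in more than one place, so their gap cannot be assigned to a single change.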